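The compounds below may be only part of what the source reports. "The series", "measured", "known", "first", "only" and "open" are said of these compounds alone.

Permeability series, notes on the step from compound 1 to compound 4. Compound 1 `COc1cccc(CNCCCNc2ccnc3cc(Oc4ccc(Cl)cc4)ccc23)c1O` gives the highest number of the three measured: in an ADME assay for permeability, using PAMPA, with a stated time of 30 min, at pH 7.4 (on this read-out lower numbers stand for lower permeability and higher numbers for higher permeability), compound 1 gives 317 10^-6 cm/s. Compound 2 `COc1ccc(F)cc1CNCCCNc1ccnc2cc(Cc3ccc(F)cc3)ccc12` gives 23 10^-6 cm/s in this assay, and compound 3 `Cc1cc(C)cc(Cc2ccc3c(NCCCNCc4ccco4)ccnc3c2)c1` gives 23 10^-6 cm/s in this assay; both of these gaps to compound 1 lie beyond the scatter. Among the compounds with values here, no pair of measured compounds differs in a single place, so no step size within the measured set is available. Compound 4 `COc1cccc(CNCCCNc2ccnc3cc(-c4ccccc4)ccc23)c1O` differs from compound 1 in one place: phenyl in place of 4-chlorophenoxy on an aromatic carbon. With nothing measured for this kind of change, a modest step downward in this assay, possibly within the scatter, is expected: a 1.8-fold lower number from compound 1 to compound 4 (0.25 log units; within the scatter). Compound 4 is expected to give 180 10^-6 cm/s, between 50 10^-6 cm/s and 450 10^-6 cm/s.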

Compound 4, apparent permeability: 237 10^-6 cm/s
For compound 4 the middle estimate is 1.3-fold (0.12 log units) below the measured one; measured number inside the range.
By their numbers in this assay, from the lowest: compounds 2 and 3 (each within the scatter of the next); then compounds 4 and 1 (each within the scatter of the next).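

In this assay, within the data shown here, the first single-place reading is a 1.3-fold lower number from compound 1 to compound 4 (0.13 log units; within the scatter) with phenyl in place of 4-chlorophenoxy on an aromatic carbon. This change removes the oxygen and the chlorine together, so the step cannot be divided between them. Nothing at hand gives a reason for the size of this step. On these data alone, how an amine, a carboxylic acid or a longer chain would read on this aromatic carbon stays open. Also open, as far as these compounds go, is whether the same change gives a similar step with other groups on the side chain.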